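A few compounds are considered here, and "the series" means these few. Any claim that something is new, unique, unknown or untested is made for them only; others in the source may bear on it.

Compound 2, `CC(C)(C)c1ccc(NS(=O)(=O)c2ccc(N3CCNC3=O)cc2)cc1`, carries a tert-butyl group on the aromatic carbon where compound 1, `O=C1NCCN1c1ccc(S(=O)(=O)Nc2ccc(I)cc2)cc1`, carries iodo. In a functional assay on HT-29 cells (Homo sapiens) for antiproliferative activity, read by sulforhodamine B assay, with a stated time of 48 h (on this read-out higher numbers stand for weaker inhibition and lower numbers for stronger inhibition), compound 1 gives 650 nM. For compound 2 this assay records only > 1000 nM, which is a limit of the assay and not a number. Among the measured compounds shown here, the single measured step, an at least 1.5-fold higher number from compound 1 to compound 2 (0.18 log units; that floor lies within the scatter), is therefore known only as a floor, and that floor lies within the scatter, as the value of compound 2 sits at the limit of > 1000 nM in this assay, at which 1 of the 2 values shown sits.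

The next compound, compound 3, `CCCCCc1ccc(NS(=O)(=O)c2ccc(N3CCNC3=O)cc2)cc1`, differs from compound 2 by pentyl in place of tert-butyl on an aromatic carbon. For the measured compounds named here, the one measured step exchanges iodo for tert-butyl and does not speak to replacing one alkyl group with another of similar size, so it gives no direction for this change. Compound 2 itself is known only as a limit, so the step from compound 2 to compound 3 can be placed only loosely. The step that the limit leaves unreadable from compound 2 to compound 3 is expected to stay within the scatter. Compound 3 is estimated at 1500 nM, within a range from 500 nM to 5000 nM, with a fair chance that this assay again reports only a limit.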

Compound 3, half-maximal inhibitory concentration: 990 nM
For compound 3 the middle estimate is 1.5-fold (0.18 log units) above the measured one; the measured number falls inside the stated range.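

In this assay, setting pentyl in place of tert-butyl on this aromatic carbon, para to a large group, gives a number no higher from compound 2 to compound 3 (the limit leaves the size open), and the pentyl group gives a readable number, which shows that an alkyl group here need not leave the result at the limit of the assay. Setting pentyl in place of iodo gives a 1.5-fold higher number from compound 1 to compound 3 (0.18 log units; within the scatter), so compound 1 and compound 3 cannot be told apart on this read-out, and this position accepts both groups without a change that exceeds the usual variation between repeated measurements. The step between tert-butyl and pentyl cannot be read, and so the two alkyl groups cannot be ranked against each other, since compound 2 is recorded only as a limit: the limit of > 1000 nM in this assay, at which 1 of the 3 values shown sits.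

From the compounds shown here alone, whether an amine, a carboxylic acid or a chain longer than pentyl at this place would move the number clearly away from that of compound 1 remains open. All three compounds share the rest of their structure, so what a change elsewhere on the shared core would do in this assay is also left open.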